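A Side Chain Added to the Ring

The compounds below may be only part of what the source reports. "The series", "measured", "known", "first", "only" and "open" are said of these compounds alone.

For the measured compounds named here, in a functional assay on L1210 cells (Mus musculus) (a lower number here means a stronger inhibitor, a higher number a weaker inhibitor), compound 1 (`O=C(/C=C/c1ccc(F)cc1)Oc1ccc(/C=C2\CCCCC2=O)cc1`) gives 30900 nM and so holds the lower of the two known numbers, while compound 2 (`O=C(/C=C/c1ccc(Cl)c(Cl)c1)Oc1ccc(/C=C2\CCCCC2=O)cc1`) gives 64800 nM as the only other value. Compound 3 (`CN(C)CC1CCC/C(=C\c2ccc(OC(=O)/C=C/c3ccc(F)cc3)cc2)C1=O`) differs from compound 1 by (dimethylamino)methyl in place of hydrogen on a saturated ring carbon in one change: (dimethylamino)methyl in place of hydrogen on a saturated ring carbon. Going by the values given here, the only measured step is a 2.1-fold higher number from compound 1 to compound 2 (0.32 log units; beyond the scatter) and it lies elsewhere on the molecule, so it offers little guidance here. The expected step in this assay is a 3.1-fold lower number from compound 1 to compound 3 (0.49 log units; beyond the scatter) and it remains a loose judgement. Compound 3 is estimated at 10000 nM within a range from 2500 nM to 40000 nM for now.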

Compound 3, half-maximal inhibitory concentration: 1840 nM
Estimate against measurement, compound 3: 5.4-fold (0.74 log units) above; the measured number lies below the stated range.
By their numbers in this assay, from the lowest: compound 3; then compound 1; then compound 2.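

In this assay, (dimethylamino)methyl in place of hydrogen on a saturated ring carbon gives a 17-fold lower number from compound 1 to compound 3 (1.23 log units; beyond the scatter). For the compounds shown here, compounds 1 and 2 carry only hydrogen at this carbon, so this is the first sign that a change here can move the number strongly, and in the direction of a stronger inhibitor. No available measurement bears on the reason for this gain.

Going by these compounds, it remains open whether a plain methyl or a piperidinylmethyl group at this carbon would do the same. On these data alone, it is also open whether (dimethylamino)methyl would give a similar step alongside the 3,4-dichlorophenyl group of compound 2.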